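Chalcone series: dichlorophenyl replacement of aminophenyl

The source may report more compounds than this note shows. Statements on the series, on what has been measured and on what is new or still open speak of the compounds shown alone.

Measured so far:
- compound 1 `COc1cc(-c2cc(/C=C/C(=O)c3ccc(N)cc3)[nH]n2)cc(OC)c1OC`: -83%
- compound 2 `COc1ccc(-c2cc(/C=C/C(=O)c3ccc(OC)c(OC)c3)[nH]n2)cc1`: -81%

In a functional assay on NCI-H522 cells (Homo sapiens) for cytotoxicity, read by sulforhodamine B assay, with a stated time of 48 h, tested at 100 uM (on this read-out lower numbers stand for a stronger effect and higher numbers for a weaker effect at the one concentration tested), compound 1 gives -83%. Compound 2, carrying a different pair of aryl groups on the shared core, gives -81% in this assay, which lies within the scatter of the number for compound 1. Compound 3 `COc1cc(-c2cc(/C=C/C(=O)c3ccc(Cl)c(Cl)c3)[nH]n2)cc(OC)c1OC` has not been measured. It differs from compound 1 by 3,4-dichlorophenyl in place of 4-aminophenyl on a carbonyl carbon. Among the compounds with values here, no step between measured compounds is known. Both measured compounds show a strong effect despite different aryl substitution, so the step from compound 1 to compound 3 is expected to be small and within the scatter, a number 7 percentage points higher from compound 1 to compound 3 (within the scatter). For compound 3 the estimate in this assay is -76%, between -95% and -40%.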

Compound 3, a percentage reported as activity, at one concentration (the size of the read-out at that concentration, not a potency): -65%
Compound 3: middle estimate off by 11 percentage points, on the low side; the measured number falls inside the stated range.
By their numbers in this assay, from the lowest: compounds 1 and 2 (each within the scatter of the next); then compound 3.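

In this assay, within the data shown here, 3,4-dichlorophenyl in place of 4-aminophenyl on a carbonyl carbon gives a number 18 percentage points higher from compound 1 to compound 3 (beyond the scatter) and so provides the first readable single-place step. This position therefore responds to a change of aryl group, although the step is modest and compound 3 at -65% still gives a negative read-out. No measurement at hand explains the step. From the compounds shown here alone, whether it follows from losing the amine or from gaining the two chlorines remains open. Unsubstituted phenyl or a monochlorophenyl at this position would separate those two changes.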